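Chloro to methoxy on the second aryl of compound 2

A few compounds are considered here, and "the series" means these few. Any claim that something is new, unique, unknown or untested is made for them only; others in the source may bear on it.

Compound 2 `COc1ccc(Cn2cc(CNC(=O)c3cn(-c4ccccc4)nc3-c3ccc(Cl)cc3)nn2)cc1` is the stronger of the two measured compounds in a functional assay on MIA PaCa-2 cells (Homo sapiens) for antiproliferative activity, read by sulforhodamine B assay, with a stated time of 48 h; on this read-out higher numbers stand for weaker inhibition of growth and lower numbers for stronger inhibition of growth: compound 2 gives 290 nM, and compound 1 `O=C(NCc1cn(Cc2ccc(C(F)(F)F)cc2)nn1)c1cn(-c2ccccc2)nc1-c1ccc(Cl)cc1` gives 1100 nM. Among the compounds with values here, the only measured step, a 3.8-fold lower number from compound 1 to compound 2 (0.58 log units; beyond the scatter), concerns methoxy in place of trifluoromethyl on an aromatic carbon. Compound 3 `COc1ccc(Cn2cc(CNC(=O)c3cn(-c4ccccc4)nc3-c3ccc(OC)cc3)nn2)cc1` differs from compound 2 elsewhere: methoxy in place of chloro on an aromatic carbon, the same difference read one bond further out being 4-chlorophenyl to 4-methoxyphenyl. Within the data shown here, no measured step touches this position, so the step from compound 1 to compound 2 bears on it only loosely, as a sign that a methoxy is tolerated on one aryl of this shared core. For compound 3 the expected change is therefore small, a 1.6-fold higher number from compound 2 to compound 3 (0.19 log units; within the scatter), with wide uncertainty. Compound 3 is estimated at 450 nM in this assay, within a range from 120 nM to 1700 nM.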

Compound 3, concentration for 50% growth inhibition: 2500 nM
Compound 3: the middle estimate sits 5.6-fold (0.74 log units) below what was measured, outside the stated range (above it).
By their numbers in this assay, from the lowest: compound 2; then compound 1; then compound 3.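

Within the data shown here, the position on the 4-chlorophenyl ring proves far less forgiving than the earlier compounds could show: in this assay the change from chloro to methoxy gives an 8.6-fold higher number from compound 2 to compound 3 (0.94 log units; beyond the scatter), a step beyond the scatter. Methoxy thus goes with opposite outcomes in the two places, since a 3.8-fold lower number from compound 1 to compound 2 (0.58 log units; beyond the scatter) marks a gain when it replaces trifluoromethyl on the other aryl, so tolerance in that place does not carry over to this one. Nothing shown explains why this change weakens growth inhibition here.

With only chloro and methoxy shown at this position, the compounds cannot separate a loss tied to removing chloro from one tied to introducing methoxy. From the compounds shown here alone, how a fluoro, a methyl, a hydroxyl or an amine would read at this place remains open.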